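Compound 3: phenethyl on the carbonyl carbon, cytotoxicity outlook

The source may report more compounds than this note shows. Statements on the series, on what has been measured and on what is new or still open speak of the compounds shown alone.

In an ADME assay on HepG2 cells (Homo sapiens) for cytotoxicity, in the presence of a further agent that is not named here (a lower number here means a stronger inhibitor, a higher number a weaker inhibitor), compound 1 (`CN(Cc1ccccc1)C(=O)c1nc(Cc2ccccc2C(F)(F)F)n(C)c(=O)c1O`) gives > 100000 nM as a limit of the assay and not a number. Compound 2 (`CCn1c(Cc2ccccc2C(F)(F)F)nc(C(=O)NCc2ccccc2)c(O)c1=O`) gives > 100000 nM as a limit too. Within the data shown here, the series so far therefore sits at one place (the limit of > 100000 nM in this assay, at which 2 of the 2 values shown sit) and compound 1 has no numeric rank within it.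

Compound 3 (`Cn1c(Cc2ccccc2C(F)(F)F)nc(C(=O)CCc2ccccc2)c(O)c1=O`) carries phenethyl in place of benzyl(methyl)amino on a carbonyl carbon. Among the measured compounds shown here, no single-change step has been measured in this assay so the size of this one cannot be read from the series. The only anchor for the expectation is compound 1 at > 100000 nM as a limit. The estimated step (a number no higher from compound 1 to compound 3 (the limit leaves the size open)) is expected to stay within the scatter, with no direction favoured. For compound 3 the estimate is 100000 nM with an expected range of 30000 nM to 200000 nM and a further limit is the likely report.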

Compound 3, half-maximal inhibitory concentration: > 100000 nM
Compound 3 was reported as a limit (the forecaster's own chance of this, stated with the estimate: 75%); the middle value lies on the limit itself.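

No step can be read between compound 1 and compound 3: in this assay both values are limits of the assay and not numbers. Still open is how far phenethyl and benzyl(methyl)amino on a carbonyl carbon differ in this assay, as no compound shown has a numeric value there.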